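Carboxyphenyl position scan on the triazole series

This account rests on a few compounds, and the source may have more. Where it says the series, first, only, none or still open, it means among the compounds named here.

Compound 2 `Nc1ccc(-c2cn(Cc3cc(C(=O)O)cc(-c4ccc(C(=O)O)cc4)c3)nn2)cc1` gives 285000 nM in an assay on cells for inhibition of ubiquitin carboxyl-terminal hydrolase isozyme L5 (Homo sapiens), read by fluorescence, with a stated time of 30 min (a lower number here means a stronger inhibitor, a higher number a weaker inhibitor), and so sits at the highest number among the two measured; compound 1 `Nc1ccc(-c2cn(Cc3cc(C(=O)O)cc(-c4ccccc4C(=O)O)c3)nn2)cc1` gives 80500 nM in this assay. Among the compounds with values here, the only step measured so far, a 3.5-fold higher number from compound 1 to compound 2 (0.55 log units; beyond the scatter), bears directly on the question. That step moves the carboxy group around the same ring. Compound 3 `Nc1ccc(-c2cn(Cc3cc(C(=O)O)cc(-c4cccc(C(=O)O)c4)c3)nn2)cc1` carries the change (3-carboxyphenyl in place of 4-carboxyphenyl on an aromatic carbon), which puts the carboxy group at the remaining position of that ring. Within the data shown here, with one step as the only guide, the carboxy group at the third position is expected to give a number between those of compound 1 and compound 2, most likely a modest drop from compound 2, i.e. a 1.9-fold lower number from compound 2 to compound 3 (0.28 log units; within the scatter) is estimated. Compound 3 is therefore expected at 150000 nM, with a range from 50000 nM to 450000 nM.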

Compound 3, half-maximal inhibitory concentration: 32900 nM
Beside the measured number, compound 3's estimate is 4.6-fold (0.66 log units) above it, outside the stated range (below it).
By their numbers in this assay, from the lowest: compound 3; then compound 1; then compound 2.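

In this assay the 3-carboxyphenyl group does not land between the other two placements: an 8.7-fold lower number from compound 2 to compound 3 (0.94 log units; beyond the scatter) and a 2.4-fold lower number from compound 1 to compound 3 (0.39 log units; beyond the scatter) together put compound 3 at the lowest number of the three, with both steps beyond the scatter. The order therefore does not run steadily as the carboxy group moves around this ring, and the largest step shown comes from a change that leaves the atoms the same. Nothing at hand accounts for this order.

Still open, on these data alone, is whether the carboxylic acid of the 3-carboxyphenyl group is itself required, or whether a primary amide or a tetrazole in its place would hold the number of compound 3. The contributions of the second carboxylic acid and the amine on the shared core also remain unresolved.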